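Side-Chain Heterocycle Replaced by a Carbamoyl Group

The source may report more compounds than this note shows. Statements on the series, on what has been measured and on what is new or still open speak of the compounds shown alone.

Compound 3 `CC(C)C(Cc1noc(=O)[nH]1)c1ccc(-c2ccc3cccc(F)c3c2)[nH]c1=O` stands with the highest of the three numbers in an assay on CHO cells for displacement of a labelled ligand from prostaglandin E2 receptor EP3 subtype (Homo sapiens), read by radioligand binding; a higher number here means a weaker inhibitor, a lower number a stronger inhibitor: compound 3 gives 34 nM. Its nearest neighbour is compound 2 `CC(C)C(c1ccc(-c2ccc3cccc(F)c3c2)[nH]c1=O)N1CCN/C1=N\C#N`, which gives 23 nM, and the step of a 1.5-fold higher number from compound 2 to compound 3 (0.17 log units; within the scatter). Compound 1 `CC(C)C(c1ccc(-c2ccc3cccc(F)c3c2)[nH]c1=O)N1CCCCS1(=O)=O` gives 14 nM, and the step of a 2.4-fold higher number from compound 1 to compound 3 (0.39 log units; beyond the scatter). Compound 4 `CC(C)C(CC(N)=O)c1ccc(-c2ccc3cccc(F)c3c2)[nH]c1=O` differs from compound 3 in this way: a group of 3 heavy atoms (1 carbon, 1 nitrogen, 1 oxygen; no ring) in place of a group of 6 heavy atoms (2 carbon, 2 nitrogen, 2 oxygen; one five-membered aromatic ring with 3 hetero atoms), on a saturated chain carbon, two bonds along the chain from an aromatic carbon. All three measured steps alter the group on the same saturated chain carbon, and their sizes were a 1.6-fold higher number from compound 1 to compound 2 (0.22 log units; within the scatter), a 2.4-fold higher number from compound 1 to compound 3 (0.39 log units; beyond the scatter) and a 1.5-fold higher number from compound 2 to compound 3 (0.17 log units; within the scatter); the entering carbamoyl brings no ring at all. Compound 4 is therefore expected to give a modestly higher number, a 2.4-fold higher number from compound 3 to compound 4 (0.37 log units; beyond the scatter). The estimate for compound 4 is 80 nM, within a range from 25 nM to 300 nM.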

Compound 4, inhibition constant: 5 nM
Compound 4: middle estimate off by 16-fold (1.20 log units), on the high side, and the stated range ends above it.
By their numbers in this assay, from the lowest: compound 4; then compounds 1, 2 and 3 (each within the scatter of the next, the first and the last beyond it).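

In this assay, the carbamoyl, which brings no ring, gives a lower number than each ring-bearing group shown here (a 6.8-fold lower number from compound 3 to compound 4 (0.83 log units; beyond the scatter); a 4.6-fold lower number from compound 2 to compound 4 (0.66 log units; beyond the scatter); a 2.8-fold lower number from compound 1 to compound 4 (0.45 log units; beyond the scatter)). Among the compounds shown here, a ring in this side chain is therefore not needed for a low number, which the earlier compounds, all ring-bearing, could not show. Nothing available explains this gain. The compounds shown leave open whether the amide hydrogens matter, which a methyl amide or a carboxylic acid in this place would test. They also leave open whether a longer chain ending in carbamoyl keeps the low number.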